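Difluoromethoxy for fluoro on the sulfonamide aryl ring

The source may report more compounds than this note shows. Statements on the series, on what has been measured and on what is new or still open speak of the compounds shown alone.

Compound 2 `O=C1NCCN1c1ccc(S(=O)(=O)Nc2ccc(F)cc2)cc1` gives 370 nM in a functional assay on HT-29 cells (Homo sapiens) for antiproliferative activity, read by sulforhodamine B assay, with a stated time of 48 h (on this read-out higher numbers stand for weaker inhibition and lower numbers for stronger inhibition), the higher of the two numbers shown; compound 1 `CCc1ccccc1NS(=O)(=O)c1ccc(N2CCNC2=O)cc1` gives 240 nM, and a 1.5-fold higher number from compound 1 to compound 2 (0.19 log units; within the scatter) lies within the scatter. Compound 3 `O=C1NCCN1c1ccc(S(=O)(=O)Nc2ccc(OC(F)F)cc2)cc1` differs from compound 2 by difluoromethoxy in place of fluoro on an aromatic carbon. Within the data shown here, the only measured step that touches the same aryl group on the sulfonamide nitrogen is a 1.5-fold higher number from compound 1 to compound 2 (0.19 log units; within the scatter), which stayed within the scatter, so no step beyond the scatter is expected here either. Compound 3 is therefore estimated at 400 nM, with a range of 150 nM to 1100 nM. This corresponds to an expected 1.1-fold higher number from compound 2 to compound 3 (0.03 log units; within the scatter).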

Compound 3, half-maximal inhibitory concentration: 650 nM
Beside the measured number, compound 3's estimate is 1.6-fold (0.21 log units) below it; the range from low to high includes it.
By their numbers in this assay, from the lowest: compounds 1, 2 and 3 (each within the scatter of the next, the first and the last beyond it).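

In this assay, difluoromethoxy in place of fluoro on this aromatic carbon gives a 1.8-fold higher number from compound 2 to compound 3 (0.24 log units; within the scatter), so the change from 1 heavy atom to 4 heavy atoms, with 1 hydrogen-bond acceptor entering, gives no step beyond the scatter. The earlier step changed both the group and its place on the ring, whereas this one holds the place fixed and changes only the group. Nothing available bears on the reason for this result. Still open, going by these compounds, is how an amine or a carboxylic acid on this carbon would read, and whether a longer chain such as propoxy would stay within the scatter of compound 2.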